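The compounds below may be only part of what the source reports. "The series", "measured", "known", "first", "only" and "open" are said of these compounds alone.

Compound 1 `COc1ccc(C2=NN(C3=NC(=O)/C(=C4\C(=O)Nc5ccc(Br)cc54)S3)C(c3ccc(OC)cc3)C2)cc1` and compound 2 `COc1ccc(C2=NN(C3=NC(=O)/C(=C4\C(=O)Nc5ccc(Cl)cc54)S3)C(c3ccc(OC)cc3)C2)cc1` share one core and differ in a single place: chloro in place of bromo on an aromatic carbon. In a functional assay on cells (Cancer cell lines, Homo sapiens) for cytotoxicity, read by sulforhodamine B assay, with a stated time of 48 h (a lower number here means a stronger inhibitor of growth, a higher number a weaker inhibitor of growth), compound 1 gives 25300 nM, while compound 2 gives 430 nM, so the change produced a 59-fold lower number from compound 1 to compound 2 (1.77 log units; beyond the scatter).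

Compound 3 `CN(C)c1ccc(C2CC(c3ccccc3)=NN2C2=NC(=O)/C(=C3\C(=O)Nc4ccc(Br)cc43)S2)cc1` has a different core; the difference between the two cores is not broken down here. In this assay compound 3 gives 420 nM, a value within the scatter of compound 2.

Compound 4 `CN(C)c1ccc(C2CC(c3ccccc3)=NN2C2=NC(=O)/C(=C3\C(=O)Nc4ccc(Cl)cc43)S2)cc1` arises from compound 3 by the same change, at the same place: chloro in place of bromo on an aromatic carbon. Among the measured compounds shown here, since compound 2 already sits near compound 3, which gives 420 nM, the step is expected to be smaller than the one from compound 1 to compound 2. For compound 4 the expected step is a 2.1-fold lower number from compound 3 to compound 4 (0.32 log units; beyond the scatter). Compound 4 is therefore estimated at 200 nM, between 50 nM and 1000 nM.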

Compound 4, concentration for total growth inhibition: 410 nM
Estimate against measurement, compound 4: 2.1-fold (0.31 log units) below, within the range that was stated.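

In this assay, the step on the second core reads a 1.0-fold lower number from compound 3 to compound 4 (0.01 log units; within the scatter), so the large step seen on the first core does not carry over. The same swap of bromo for chloro therefore cannot be assumed to have the same size on both cores: the same change on two cores in this assay, a 59-fold lower number (1.77 log units; beyond the scatter) from compound 1 to compound 2 and a 1.0-fold lower number (0.01 log units; within the scatter) from compound 3 to compound 4, 57-fold (1.76 log units) apart, beyond the scatter of two such steps. This does not show which feature of the cores accounts for the gap, and two cores give no rule for the rest of the series.

The compounds shown leave open how fluoro, a methyl group or a plain hydrogen would behave on the same aromatic carbon. They also leave open whether the outcome for those groups would depend on the core.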